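This account rests on a few compounds, and the source may have more. Where it says the series, first, only, none or still open, it means among the compounds named here.

Measured so far in a functional assay on SW480 cells (Homo sapiens) for cytotoxicity, read by MTT assay, with a stated time of 24 h; on this read-out lower numbers stand for stronger inhibition and higher numbers for weaker inhibition:
- compound 1, `C=CC1=C(C(=O)Nc2ccc(OCC)cc2)C(c2ccc(OC)cc2)OC1`: compound 1 gives > 100000 nM, a limit of the assay.
- compound 2, `C=CC1=C(C(=O)NC2CCCCC2)C(c2ccc(OC)c(OC)c2)OC1`: compound 2 gives 19100 nM.
- compound 3, `C=CC1=C(C(=O)Nc2ccccc2)C(c2ccc(OC)cc2)OC1`: compound 3 gives > 100000 nM, a limit of the assay.

Compound 3 stands at the limit of this assay, where two of the three values sit (the limit of > 100000 nM in this assay, at which 2 of the 3 values shown sit). The one listed step, a step that the two limits leave unreadable from compound 1 to compound 3, is unreadable for the same reason: both ends are limits. Within the data shown here, compound 2, the only entry with a number, is the only one carrying a cyclohexyl on the amide nitrogen; it also carries a second methoxy on the other aromatic ring, and no step to compound 3 is given for it.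

Compound 4, `C=CC1=C(C(=O)NC2CCCCC2)C(c2ccc(OC)cc2)OC1`, comes from compound 3 by the change (cyclohexyl in place of phenyl on an amide-type nitrogen). Among the measured compounds shown here, no measured step covers this change directly. For the measured compounds named here, the only numbered compound, compound 2, shares the cyclohexylamino part, and its value of 19100 nM is the nearest guide. The step of an at least 2.8-fold lower number from compound 3 to compound 4 (0.45 log units; beyond the scatter) is therefore expected to move off the limit toward stronger inhibition, but a limit remains possible. Compound 4 is estimated at 35000 nM in this assay, with a range from 10000 nM to 100000 nM.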

Compound 4, half-maximal inhibitory concentration: > 100000 nM
Compound 4 ended at the assay's limit (the forecaster's own chance of this, stated with the estimate: 35%); middle value at least 2.8-fold (0.45 log units) away from the limit.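

In this assay compound 4 gives > 100000 nM, a limit of the assay, so cyclohexyl in place of phenyl on an amide-type nitrogen does not on its own bring the series onto the measurable scale. The change that does separate two compounds is the loss of one methoxy, with an at least 5.2-fold higher number from compound 2 to compound 4 (0.71 log units; beyond the scatter), so the number for compound 2 depends on its second methoxy and not on the cyclohexyl alone, which compound 2 by itself could not show. The steps to compound 4 from compound 3 and from compound 1 cannot be read because both ends of each are limits: the limit of > 100000 nM in this assay, at which 3 of the 4 values shown sit.

Still open, as far as these compounds go, is how far compound 4 really lies past the limit, and so the full size of the methoxy step, as well as whether the second methoxy would have any effect with phenyl or 4-ethoxyphenyl on the amide nitrogen. Also open, from the compounds shown here alone, is how a hydroxy or a fluorine in the place of that methoxy, or a cyclopentyl or a longer alkyl chain on the amide nitrogen, would read in this assay.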